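Carrying one substituent swap onto a second core

The source may hold more compounds than are shown below. What is called first, only, known or untested is meant among the compounds shown, and "the series" means these compounds.

Measured so far in an assay on isolated protein for inhibition of DNA topoisomerase 1 (Homo sapiens), with a stated time of 15 min; on this read-out higher numbers stand for weaker inhibition and lower numbers for stronger inhibition:
compound 1, `O=C(O)c1cn(Cc2ccc(-c3ccccc3)cc2)c2cc(N3CC4CNCC4C3)c(F)cc2c1=O`, gives 33300 nM
compound 2, `NC[C@@H]1CCN(c2cc3c(cc2F)c(=O)c(C(=O)O)cn3Cc2ccc(-c3ccccc3)cc2)C1`, gives 15600 nM
compound 3, `O=C(O)c1cn(Cc2ccc(-n3cccn3)cc2)c2cc(N3CC4CNCC4C3)c(F)cc2c1=O`, gives 173000 nM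

Compound 4 `NC[C@@H]1CCN(c2cc3c(cc2F)c(=O)c(C(=O)O)cn3Cc2ccc(-n3cccn3)cc2)C1` is not yet measured in this assay. It stands to compound 3 as compound 2 stands to compound 1: the change a group of 7 heavy atoms (5 carbon, 2 nitrogen; one five-membered non-aromatic ring with 1 hetero atom) in place of a group of 8 heavy atoms (6 carbon, 2 nitrogen; 2 five-membered non-aromatic rings with 1 hetero atom each), on an aromatic carbon is the same as a group of 7 heavy atoms (5 carbon, 2 nitrogen; one five-membered non-aromatic ring with 1 hetero atom) in place of a group of 8 heavy atoms (6 carbon, 2 nitrogen; 2 five-membered non-aromatic rings with 1 hetero atom each), on an aromatic carbon, with the place described in the same words. Compound 3 and compound 4 differ in core from compound 1 and compound 2 by 1H-pyrazol-1-yl in place of phenyl on an aromatic carbon, and that core change gave a 5.2-fold higher number from compound 1 to compound 3 (0.72 log units; beyond the scatter). Among the compounds with values here, the one measured instance of the substituent swap gave a 2.1-fold lower number from compound 1 to compound 2 (0.33 log units; beyond the scatter). A step of similar size is expected from compound 3 to compound 4, a 2.0-fold lower number from compound 3 to compound 4 (0.31 log units; beyond the scatter), because a 2.1-fold lower number from compound 1 to compound 2 (0.33 log units; beyond the scatter) is the only precedent and nothing shown tests whether the core alters it. Compound 4 is therefore estimated at 85000 nM, between 35000 nM and 200000 nM, a wide range given a single precedent.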

Compound 4, half-maximal inhibitory concentration: 91600 nM
Compound 4: the middle estimate sits 1.1-fold (0.03 log units) below what was measured; low and high end bracket the measured number.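

In this assay, the swap to 3-(aminomethyl)pyrrolidin-1-yl gave a 1.9-fold lower number from compound 3 to compound 4 (0.28 log units; within the scatter) and so repeated on the second core what it did on the first: the same change on two cores in this assay, a 2.1-fold lower number (0.33 log units; beyond the scatter) from compound 1 to compound 2 and a 1.9-fold lower number (0.28 log units; within the scatter) from compound 3 to compound 4, 1.1-fold (0.05 log units) apart, within the scatter of two such steps.
The change to 1H-pyrazol-1-yl, read on the other pair, gave a 5.9-fold higher number from compound 2 to compound 4 (0.77 log units; beyond the scatter) and agreed just as closely: the same change on two cores in this assay, a 5.2-fold higher number (0.72 log units; beyond the scatter) from compound 1 to compound 3 and a 5.9-fold higher number (0.77 log units; beyond the scatter) from compound 2 to compound 4, 1.1-fold (0.05 log units) apart, within the scatter of two such steps.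
Across these four compounds the two changes therefore act independently of each other, but this rests on two cores only, and the step on the second core does not by itself stand clear of the scatter.

The compounds shown leave open whether this agreement extends to other groups on that aromatic carbon, such as a piperazine or an open-chain amine. They also leave open whether it survives an amide in place of the carboxylic acid.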